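The compounds below may be only part of what the source reports. "The series", "measured", "known", "first", "only" and "open" are said of these compounds alone.

Working notes on the series. Two compounds have been run in a functional assay on A549 cells (Homo sapiens) for cytotoxicity, read by sulforhodamine B assay, with a stated time of 3 days; a lower number here means that less compound is needed, a higher number that more compound is needed for the effect: compound 1 `CCOc1c(-c2occ(C)c2CO)ccc2c1CCCC2(C)C` and compound 2 `COc1c(-c2occ(C)c2COC(C)=O)ccc2c1CCCC2(C)C`. In this assay compound 1 gives 22.9 uM. In this assay compound 2 gives 28.7 uM, the highest of the two numbers; its nearest neighbour is compound 1, and the gap between the two lies within the scatter. Compound 3 `COc1c(-c2occ(C)c2CO)ccc2c1CCCC2(C)C` has not yet been measured in this assay. It differs from compound 2 by hydrogen in place of acetyl on an oxygen on a saturated carbon. For the measured compounds named here, no step between measured compounds with this change is recorded. Compound 1 carries the same hydroxymethyl group that compound 3 carries, and compound 1 sits at 22.9 uM, within the scatter of compound 2, so the expected step of a 1.1-fold lower number from compound 2 to compound 3 (0.06 log units; within the scatter) is none beyond the scatter in either direction. Compound 3 is estimated at 25 uM in this assay, with a range of 11 uM to 55 uM.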

Compound 3, concentration for half-maximal effect: 23.3 uM
Beside the measured number, compound 3's estimate is 1.1-fold (0.03 log units) above it; low and high end bracket the measured number.
By their numbers in this assay, from the lowest: compounds 1, 3 and 2 (each within the scatter of the next).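

In this assay, hydrogen in place of acetyl on an oxygen on a saturated carbon, the change from acetoxymethyl to hydroxymethyl, gives a 1.2-fold lower number from compound 2 to compound 3 (0.09 log units; within the scatter) and so now has a directly measured step, which shows that this change alone does not move the number beyond the scatter. Hydrogen in place of methyl on a saturated chain carbon bound to an oxygen on an aromatic ring gives a 1.0-fold higher number from compound 1 to compound 3 (0.01 log units; within the scatter) and likewise stays within the scatter, so neither place has yet produced a readable difference. No measurement at hand bears on the reason for these small steps.

On these data alone, whether a different group at either place would move the number stays open, for example an amine or a carboxylic acid in place of the hydroxy, or a longer chain on the oxygen on the aromatic ring. As far as these compounds go, whether these close numbers would hold in other cell lines also stays open.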